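Changing the Amide Group of Compound 3

This account rests on a few compounds, and the source may have more. Where it says the series, first, only, none or still open, it means among the compounds named here.

Three amides sharing one core have been measured in a functional assay on A549 cells (Homo sapiens) for antiproliferative activity, read by MTT assay, with a stated time of 72 h; on this read-out higher numbers stand for weaker inhibition and lower numbers for stronger inhibition. Compound 1 `C/C=C/C(=O)Nc1cccc(Oc2nc(Nc3cccc(OC)c3)nc3c2CSCC3)c1` gives 21100 nM, compound 2 `CC/C=C/C(=O)Nc1cccc(Oc2nc(Nc3cccc(OC)c3)nc3c2CSCC3)c1` gives 17200 nM, and compound 3 `COc1cccc(Nc2nc3c(c(Oc4cccc(NC(=O)C=C(C)C)c4)n2)CSCC3)c1` gives 19800 nM. Compound 3 therefore sits level with the other two, and all three values lie within the scatter of each other. The next compound, compound 4 `C=C(F)C(=O)Nc1cccc(Oc2nc(Nc3cccc(OC)c3)nc3c2CSCC3)c1`, carries 1-fluoroethenyl in place of 2-methylprop-1-en-1-yl on a carbonyl carbon.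

Two measured steps changed the group at this same place, a 1.1-fold lower number from compound 1 to compound 3 (0.03 log units; within the scatter) and a 1.2-fold higher number from compound 2 to compound 3 (0.06 log units; within the scatter). A third, a 1.2-fold lower number from compound 1 to compound 2 (0.09 log units; within the scatter), altered the same chain. All were small, so this assay has so far shown little response to changes here. However, no measured compound carries 1-fluoroethenyl, so these steps are only an indirect guide and the uncertainty is wide. The expected change is slight, toward a lower number but not beyond the scatter, with an estimated step of a 1.5-fold lower number from compound 3 to compound 4 (0.18 log units; within the scatter). For compound 4 the estimated value is 13000 nM, with an expected range from 4000 nM to 30000 nM.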

Compound 4, half-maximal inhibitory concentration: 29600 nM
Compound 4: middle estimate off by 2.3-fold (0.36 log units), on the low side; the range from low to high includes it.
By their numbers in this assay, from the lowest: compounds 2, 3, 1 and 4 (each within the scatter of the next).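

In this assay, the fluorine-bearing 1-fluoroethenyl group, the first one here with an atom other than carbon in this group on the carbonyl carbon, leaves the number within the scatter of all three earlier amides (a 1.5-fold higher number from compound 3 to compound 4 (0.17 log units; within the scatter); a 1.7-fold higher number from compound 2 to compound 4 (0.24 log units; within the scatter); a 1.4-fold higher number from compound 1 to compound 4 (0.15 log units; within the scatter)). For the compounds shown here, the flat response seen among the 2-methylprop-1-en-1-yl, but-1-en-1-yl and prop-1-en-1-yl amides therefore extends to a group with a fluorine and with fewer heavy atoms, and no compound in the set stands apart from the others. No measurement available here helps to interpret this result.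

As far as these compounds go, whether an amine, a carboxylic acid or a longer chain on this carbonyl carbon would move the number beyond the scatter remains open. So does the effect of a saturated chain in place of the double bond.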